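The compounds below may be only part of what the source reports. "The series", "measured", "known", "first", "only" and "open" are said of these compounds alone.

In a functional assay on MCF7 cells (Homo sapiens) for antiproliferative activity, read by MTT assay, with a stated time of 48 h (a lower number here means a stronger inhibitor, a higher number a weaker inhibitor), compound 1 (`Fc1ccc(NCc2cn(-c3ccccc3)nc2-c2ccc(Cl)cc2)cc1`) gives 1880 nM and compound 2 (`COc1ccc(-c2nn(-c3ccccc3)cc2CNc2ccc(C)cc2)cc1`) gives 8160 nM which is the higher of the two numbers, so compound 2 is the weaker inhibitor by a gap beyond the scatter of repeat measurements. Compound 3 (`COc1ccc(-c2nn(-c3ccccc3)cc2CNc2ccc(F)cc2)cc1`) differs from compound 2 in one place, with fluoro in place of methyl on an aromatic carbon. Among the compounds with values here, no measured pair shows this change alone, so only a small step toward a lower number is expected (a 1.8-fold lower number from compound 2 to compound 3 (0.26 log units; within the scatter)). In this assay compound 3 is estimated to give 4500 nM within a range from 1800 nM to 11000 nM as the expected span.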

Compound 3, half-maximal inhibitory concentration: 5980 nM
Compound 3: middle estimate off by 1.3-fold (0.12 log units), on the low side; low and high end bracket the measured number.
By their numbers in this assay, from the lowest: compound 1; then compounds 3 and 2 (each within the scatter of the next).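

In this assay, fluoro and methyl on this aromatic carbon cannot be told apart: a 1.4-fold lower number from compound 2 to compound 3 (0.13 log units; within the scatter). A change in another place does register, with methoxy in place of chloro giving a 3.2-fold higher number from compound 1 to compound 3 (0.50 log units; beyond the scatter). Nothing available explains either step. Going by these compounds, whether an amine or a carboxylic acid at the fluoro position would shift the number beyond the scatter remains open. So does whether the gap between methoxy and chloro would hold with methyl instead of fluoro on the other aromatic ring.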